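Removing One 3-Methylbut-2-en-1-yl Group from Compound 3

The compounds below may be only part of what the source reports. "The series", "measured", "known", "first", "only" and "open" are said of these compounds alone.

Measured so far in a functional assay on HT-29 cells (Homo sapiens) for cytotoxicity, read by XTT assay, with a stated time of 72 h; a lower number here means a stronger inhibitor, a higher number a weaker inhibitor:
compound 1 `CC(=O)c1c(O)cc(O)cc1OC/C=C(\C)CC/C=C(\C)CCC=C(C)C` gives 31000 nM;
compound 2 `CC(C)=CCC/C=C(\C)Cc1c(O)cc(O)c2c(=O)cc(-c3ccccc3)oc12` gives 32000 nM;
compound 3 `CC(=O)c1c(O)c(CC=C(C)C)c(O)c(CC=C(C)C)c1O` gives > 100000 nM.

For the measured compounds named here, for compound 3 that entry is only a limit of this assay, not a number, and it is the one value sitting at the limit of > 100000 nM in this assay, at which 1 of the 3 values shown sits. Compounds 1 and 2 lie within the scatter of each other. Compound 4 `CC(=O)c1c(O)cc(O)c(CC=C(C)C)c1O` differs from compound 3 in one place: hydrogen in place of 3-methylbut-2-en-1-yl on an aromatic carbon. Going by the values given here, no step between measured compounds is available to gauge this change, and compound 3 itself offers only a limit. The step expected here, an at least 1.1-fold lower number from compound 3 to compound 4 (0.04 log units; that floor lies within the scatter), is small and not clearly beyond the scatter. Compound 4 is therefore estimated at 90000 nM, within 30000 nM to 300000 nM, and may again be reported only as a limit.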

Compound 4, half-maximal inhibitory concentration: 28000 nM
For compound 4 the middle estimate is 3.2-fold (0.51 log units) above the measured one, and the stated range ends above it.
By their numbers in this assay, from the lowest: compounds 4, 1 and 2 (each within the scatter of the next). At a limit, above all of these: compound 3.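

In this assay, for the compounds shown here, replacing one 3-methylbut-2-en-1-yl group with hydrogen on this aromatic carbon gives an at least 3.5-fold lower number from compound 3 to compound 4 (0.55 log units; beyond the scatter), the first reading of this change, and it lies beyond the scatter. On this carbon, ortho to two hydroxy groups, the extra 3-methylbut-2-en-1-yl group therefore goes with the weaker result. The entry for compound 3 is a limit, not a number, so the step is only a floor: the limit of > 100000 nM in this assay, at which 1 of the 4 values shown sits.

The compounds shown leave open what a methyl group, an amine or a carboxylic acid on this carbon would do. They also leave open whether a longer chain here would behave like 3-methylbut-2-en-1-yl.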